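The compounds below may be only part of what the source reports. "The series", "measured", "known", "first", "only" and "open" are said of these compounds alone.

Measured so far:

Compound 1 `O=C(Nc1ccc(Cl)cc1)c1c(NO)cc(-c2ccccc2)oc1=O`: in an ADME assay on Huh-7 cells (Homo sapiens) for cytotoxicity, read by a luciferase reporter and WST assay, with a stated time of 3 days (on this read-out lower numbers stand for higher toxicity in this test and higher numbers for lower toxicity in this test), compound 1 gives > 20000 nM, which is a limit of the assay and not a number.
Compound 2 `O=C(Nc1ccc(Br)cc1)c1c(NO)cc(-c2ccccc2)oc1=O`: compound 2 gives > 20000 nM, again a limit.
Compound 3 `COc1ccc(NC(=O)c2c(NO)cc(-c3ccccc3)oc2=O)cc1`: compound 3 gives > 20000 nM, also a limit.

All three values sit at the same limit (the limit of > 20000 nM in this assay, at which 3 of the 3 values shown sit), so none of the three compounds shows measurable toxicity in this test. The steps between them are therefore unreadable: a step that the two limits leave unreadable from compound 1 to compound 2, a step that the two limits leave unreadable from compound 1 to compound 3 and a step that the two limits leave unreadable from compound 2 to compound 3. Compound 3 thus stands exactly where the other two stand, at the limit, and no ordering among the three can be made.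

The next compound, compound 4 `COC(=O)c1ccc(NC(=O)c2c(NO)cc(-c3ccccc3)oc2=O)cc1`, differs from compound 3 in one place: methoxycarbonyl in place of methoxy on an aromatic carbon. The measured steps that change the same position, from chloro to bromo and from either halogen to methoxy, all ended at the limit, and none of them introduces a methoxycarbonyl group. Among the compounds with values here, there is therefore no measured step that shows a change in toxicity at this position, and the expectation is that compound 4 also stays at the limit. Compound 4 is estimated to give about 30000 nM, with a range from 10000 nM to 100000 nM. This estimate means an expected step that the limit leaves unreadable from compound 3 to compound 4, which would most likely again not be readable against the limit.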

Compound 4, half-maximal cytotoxic concentration: > 20000 nM
Compound 4: only a limit was reported; the forecaster's own chance of this, stated with the estimate: 80%; the middle value does not contradict the limit.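

Compound 4 also gives a limit and not a number, so no step among compound 1, compound 2, compound 3 and compound 4 can be read in this assay: the limit of > 20000 nM in this assay, at which 4 of the 4 values shown sit.

The compounds shown leave open whether chloro, bromo, methoxy and methoxycarbonyl differ at all in toxicity in this assay, and at what concentration, if any, each compound would become toxic.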